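Working notes: ethyl replaced by methylfuranyl at the ring carbon

The compounds below may be only part of what the source reports. "The series", "measured", "known", "first", "only" and "open" are said of these compounds alone.

Of the compounds shown here, three have been measured in an assay for inhibition of beta-glucuronidase (Bos taurus), read by spectrophotometry, with a stated time of 30 min; a higher number here means a weaker inhibitor, a lower number a stronger inhibitor. Compound 1 `COC(=O)C1=C(C)NC(=O)NC1c1ccc(OC)c(OC)c1` gives "not active" (no number reported) in this assay. Compound 2 `COC(=O)C1=C(C)NC(=O)NC1c1cc(OC)c(O)c(OC)c1` gives 34200 nM. Compound 3 `CCC1NC(=O)NC(C)=C1C(=O)OC` gives 52200 nM, the highest of the two numbers reported; its nearest neighbour is compound 2, and that gap lies within the scatter, so the two cannot be ranked against each other. Compound 4 `COC(=O)C1=C(C)NC(=O)NC1c1ccc(C)o1` is not yet measured. Relative to compound 3 it carries 5-methylfuran-2-yl in place of ethyl on a saturated ring carbon. Among the compounds with values here, no pair of measured compounds differs in one place only, so no measured step guides this change; compound 2 and compound 3 sit within scatter of each other, and compound 1 gave no number at all. On this basis no shift beyond the scatter is expected in either direction for compound 4. The estimate for compound 4 in this assay is 42000 nM, with a range from 15000 nM to 120000 nM. The expected step of a 1.2-fold lower number from compound 3 to compound 4 (0.09 log units; within the scatter) is essentially flat. A report without a number, as for compound 1 with "not active" (no number reported), is also possible.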

Compound 4, half-maximal inhibitory concentration: 44200 nM
Beside the measured number, compound 4's estimate is 1.1-fold (0.02 log units) below it; the range from low to high includes it.
By their numbers in this assay, from the lowest: compounds 2, 4 and 3 (each within the scatter of the next).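

In this assay the swap of ethyl for 5-methylfuran-2-yl on the saturated ring carbon gives a 1.2-fold lower number from compound 3 to compound 4 (0.07 log units; within the scatter) and is the only step shown between compounds that differ in one place. At this position, going from 2 heavy atoms without a ring to 6 heavy atoms with a five-membered aromatic ring and one hydrogen-bond acceptor therefore leaves the number within the scatter. Nothing on hand offers an explanation for this flat step.

A single step cannot show whether this ring carbon tolerates change in general or whether the two groups merely happen to read alike. On these data alone, whether a longer chain such as hexyl, an aminomethyl group or a carboxylic acid at this ring carbon would move the number beyond the scatter remains open.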